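Bromo for methoxy: from compound 2 to compound 3

The source may hold more compounds than are shown below. What is called first, only, known or untested is meant among the compounds shown, and "the series" means these compounds.

Among the measured compounds shown here, in an ADME assay on L929 cells (Mus musculus) for cytotoxicity, read by resazurin assay, with a stated time of 96 h (on this read-out higher numbers stand for lower toxicity in this test and lower numbers for higher toxicity in this test), compound 2 (`COc1cccc(OC/C(=N\NC(N)=S)c2ccc(Br)cc2)c1`) gives 50700 nM as the higher of the two numbers so far, and compound 1 (`CC(C)c1ccc(OC/C(=N\NC(N)=S)c2ccc(Br)cc2)cc1`) gives 24600 nM as the lower, a gap beyond the usual scatter. Compound 3 (`NC(=S)N/N=C(\COc1cccc(Br)c1)c1ccc(Br)cc1`) carries bromo in place of methoxy on an aromatic carbon meta to a large group. For the measured compounds named here, no measured pair shows this change, so the expectation in this assay is tentative. The estimated step of a 1.6-fold lower number from compound 2 to compound 3 (0.20 log units; within the scatter) points toward a lower number and stays within the scatter. Compound 3 is expected at 32000 nM in this test, with an estimated range from 13000 nM to 75000 nM overall.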

Compound 3, half-maximal cytotoxic concentration: > 180000 nM
Compound 3: a limit, no number; the forecaster's own chance of this, stated with the estimate: 5%; middle value at least 5.6-fold (0.75 log units) away from the limit.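

The change from methoxy to bromo on this aromatic carbon, meta to a large group, gives an at least 3.5-fold higher number from compound 2 to compound 3 (0.55 log units; beyond the scatter), the first step shown between compounds that differ in one place. It shows that a single group at this position can move the result in this assay beyond the scatter, toward lower toxicity in this test. Compound 3 stands at a limit and not at a number, so the full size of the step stays unknown: the limit of > 180000 nM in this assay, at which 1 of the 3 values shown sits.

The compounds shown leave open whether an amine, a carboxylic acid or a longer chain at this carbon would give a similar shift. They also leave open whether bromo would do the same at other positions on this aromatic ring.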